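A few compounds are considered here, and "the series" means these few. Any claim that something is new, unique, unknown or untested is made for them only; others in the source may bear on it.

Measured compounds:
- compound 1, `COc1cc2ncnc(Nc3ccc(NC(=O)c4cccc(F)c4)cc3)c2cc1OC`: in a functional assay on MCF7 cells (Homo sapiens) for inhibition, read by MTT assay (a lower number here means a stronger inhibitor, a higher number a weaker inhibitor), compound 1 gives 13600 nM
- compound 2, `COc1cc2ncnc(Nc3ccc(NC(=O)c4ccccc4Cl)cc3)c2cc1OC`: compound 2 gives 36000 nM
- compound 3, `COc1cc2ncnc(Nc3ccc(NC(=O)c4ccc(Br)cc4)cc3)c2cc1OC`: compound 3 gives 43000 nM

Among these three, compound 1 has the lowest number, and its distance to each of the other two is beyond the scatter: a 2.6-fold higher number from compound 1 to compound 2 (0.42 log units; beyond the scatter) and a 3.2-fold higher number from compound 1 to compound 3 (0.50 log units; beyond the scatter). Compound 2 and compound 3 lie within the scatter of each other, a 1.2-fold higher number from compound 2 to compound 3 (0.08 log units; within the scatter).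

The next compound, compound 4, `COc1cc2ncnc(Nc3ccc(NC(=O)c4ccc(C(F)(F)F)cc4)cc3)c2cc1OC`, shares the core of compound 1 and differs from it in one place: 4-(trifluoromethyl)phenyl in place of 3-fluorophenyl on a carbonyl carbon. The two measured steps that bear on this are the ones leaving the 3-fluorophenyl of compound 1 for another substituted phenyl on the same carbonyl carbon, and both gave a modest rise in the number. The closest comparison is the 4-bromophenyl of compound 3, because a 3.2-fold higher number from compound 1 to compound 3 (0.50 log units; beyond the scatter) shows what happens when a different single substituent sits on that ring. A modest rise, in the same direction and of similar size, is therefore expected for this assay: the expected step is a 2.6-fold higher number from compound 1 to compound 4 (0.41 log units; beyond the scatter). Compound 4 is thus estimated at 35000 nM, with a likely range from 12000 nM to 100000 nM.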

Compound 4, half-maximal inhibitory concentration: > 100000 nM
Compound 4: a limit, no number; the forecaster's own chance of this, stated with the estimate: 15%; middle value at least 2.8-fold (0.45 log units) from the limit.
By their numbers in this assay, from the lowest: compound 1; then compounds 2 and 3 (each within the scatter of the next). At a limit, above all of these: compound 4.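

In this assay compound 4 gives only a limit and no number: the limit of > 100000 nM in this assay, at which 1 of the 4 values shown sits.

Even so, the move to 4-(trifluoromethyl)phenyl on this carbonyl carbon gives an at least 7.3-fold higher number from compound 1 to compound 4 (0.86 log units; beyond the scatter), a larger step than any seen among the first three compounds, so this position is more sensitive to the choice of substituted phenyl than those compounds showed. Exchanging only the group on the aromatic carbon gives an at least 2.3-fold higher number from compound 3 to compound 4 (0.36 log units; beyond the scatter), and the comparison with the 2-chlorophenyl gives an at least 2.7-fold higher number from compound 2 to compound 4 (0.44 log units; beyond the scatter), so compound 4 stands apart from two compounds that lie within the scatter of each other.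

As far as these compounds go, how far compound 4 lies past its limit remains unknown, so the full size of these steps stays open. Also open, from the compounds shown here alone, is where an amine or a carboxylic acid on this phenyl ring would fall relative to compound 1.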